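Octadecylamide threonine series: furan to thiophene swap

The compounds below may be only part of what the source reports. "The series", "measured", "known", "first", "only" and "open" are said of these compounds alone.

Measured so far in a functional assay on SiHa cells (Homo sapiens) for cytotoxicity, read by MTT assay, with a stated time of 48 h; a higher number here means a weaker inhibitor, a lower number a stronger inhibitor:
compound 1, `CCCCCCCCCCCCCCCCCCNC(=O)[C@@H](N)[C@@H](C)O`, 39500 nM
compound 2, `CCCCCCCCNC(=O)[C@@H](NC(=O)c1cccs1)[C@@H](C)O`, 91900 nM
compound 3, `CCCCCCCCCCCCCCCCCCNC(=O)[C@@H](NC(=O)c1ccco1)[C@@H](C)O`, 13400 nM

Compound 3 holds the lowest number of the three in this assay. Going by the values given here, the one single-point step recorded is a 2.9-fold lower number from compound 1 to compound 3 (0.47 log units; beyond the scatter), which places the (furan-2-yl)carbonyl group on the amine nitrogen. Compound 2 carries a (thiophen-2-yl)carbonyl group but on an octyl chain rather than the octadecyl chain of compounds 1 and 3, so compound 2 and compound 3 differ in two places. Compound 2 gives 91900 nM and compound 3 gives 13400 nM, but this gap cannot be read as a test of the ring alone.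

Compound 4, `CCCCCCCCCCCCCCCCCCNC(=O)[C@@H](NC(=O)c1cccs1)[C@@H](C)O`, is compound 3 with thiophen-2-yl in place of furan-2-yl on a carbonyl carbon. Among the compounds with values here, no measured step bears on this exchange: the thiophene of compound 2 is confounded with the shorter chain. With nothing to separate the two rings, the expected step in this assay is none beyond the scatter, a 1.0-fold lower number from compound 3 to compound 4 (0.01 log units; within the scatter). Compound 4 is therefore estimated at 13000 nM, with a range from 5000 nM to 35000 nM.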

Compound 4, half-maximal inhibitory concentration: 117000 nM
Compound 4: the middle estimate sits 9.0-fold (0.95 log units) below what was measured, and the stated range ends below it.
By their numbers in this assay, from the lowest: compound 3; then compound 1; then compounds 2 and 4 (each within the scatter of the next).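

In this assay the ring on the carbonyl carbon proves decisive at the octadecyl chain length, with an 8.7-fold higher number from compound 3 to compound 4 (0.94 log units; beyond the scatter) for an exchange of oxygen for sulfur that leaves the heavy-atom and hydrogen-bond counts unchanged. Acylation of the amine nitrogen therefore has no single direction in these compounds: the furan-2-yl amide gives a 2.9-fold lower number from compound 1 to compound 3 (0.47 log units; beyond the scatter) in contrast, while the thiophen-2-yl amide gives a 3.0-fold higher number from compound 1 to compound 4 (0.47 log units; beyond the scatter) in this series. Among the thiophen-2-yl amides, chain length shows no separation, with a 1.3-fold higher number from compound 2 to compound 4 (0.10 log units; within the scatter) on adding decyl.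

No evidence on hand accounts for the gap between the two rings. Open, on these data alone, are whether the furan-2-yl advantage persists on the octyl chain, and where a phenyl or pyrrol-2-yl group on the carbonyl would fall.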